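Silyl ether to free hydroxyl on a shared cyclopentenone-type core

The compounds below may be only part of what the source reports. "The series", "measured", "known", "first", "only" and "open" are said of these compounds alone.

Measured compounds:
compound 1 `COc1ccc(C2=C(c3cc(OC)c(OC)c(OC)c3)C(=O)C(O[SiH2]C(C)(C)C)C2)cc1OC(C)C` — > 100 ug/mL
compound 2 `COc1ccc(C2=C(c3cc(OC)c(OC)c(OC)c3)C(=O)C(OC(C)=O)C2)cc1` — 18 ug/mL

In an ADME assay on ECV-304 cells (Homo sapiens) for cytotoxicity, read by MTT assay, with a stated time of 72 h (on this read-out higher numbers stand for weaker inhibition and lower numbers for stronger inhibition), compound 1 gives only a limit, > 100 ug/mL, so no number is known for it; it sits at the limit of > 100 ug/mL in this assay, at which 1 of the 2 values shown sits. Compound 2 gives 18 ug/mL in this assay. Compound 3 `COc1ccc(C2=C(c3cc(OC)c(OC)c(OC)c3)C(=O)C(O)C2)cc1OC(C)C` is not yet measured. It differs from compound 1 as follows: a hydrogen atom in place of a group of 5 heavy atoms (4 carbon, 1 silicon; no ring), on an oxygen on a saturated carbon. For the measured compounds named here, no measured step is available for this change, so the expectation rests on compound 1 alone, whose limit leaves the direction open. A move toward stronger inhibition is expected, of the size an at least 3.3-fold lower number from compound 1 to compound 3 (0.52 log units; beyond the scatter), though a further limit remains possible. For compound 3 the estimated value in this assay is 30 ug/mL, between 8 ug/mL and 100 ug/mL.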

Compound 3, half-maximal inhibitory concentration: > 100 ug/mL
Compound 3 ended at the assay's limit; the forecaster's own chance of this, stated with the estimate: 30%; middle value at least 3.3-fold (0.52 log units) away from the limit.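

Compound 1 and compound 3 both stand only as limits in this assay, so no step between them can be read: the limit of > 100 ug/mL in this assay, at which 2 of the 3 values shown sit.

Going by these compounds, whether a hydrogen atom in place of the group of 5 heavy atoms changes inhibition at all stays open.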